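Replacing dichlorophenyl with trifluoromethylphenyl on the acyl arm

This account rests on a few compounds, and the source may have more. Where it says the series, first, only, none or still open, it means among the compounds named here.

Three analogues share one core and were examined in a functional assay on HeLa cells (Homo sapiens) for inhibition, read by MTT assay, with a stated time of 72 h; on this read-out lower numbers stand for stronger inhibition and higher numbers for weaker inhibition. Compound 1 `CN(C(=O)NC(=O)c1cccc(C(F)(F)F)c1)c1nc(C(F)(F)F)c(C(=O)N/N=C/c2cccc(C(F)(F)F)c2)s1` gives 4.81 ug/mL. Compound 2 `CN(C(=O)NC(=O)c1ccc(Cl)cc1Cl)c1nc(C(F)(F)F)c(C(=O)N/N=C/c2ccc(C(F)(F)F)cc2)s1` gives 7.99 ug/mL. Compound 3 `CN(C(=O)NC(=O)c1ccccc1)c1nc(C(F)(F)F)c(C(=O)N/N=C/c2cccc([N+](=O)[O-])c2)s1` gives 11.2 ug/mL. Compound 2 stands second highest of the three numbers; its nearest neighbour is compound 3, within the scatter, and its furthest is compound 1, also within the scatter, so the three measured values cannot be told apart with confidence.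

The next compound to be considered is compound 4 `CN(C(=O)NC(=O)c1ccc(C(F)(F)F)cc1)c1nc(C(F)(F)F)c(C(=O)N/N=C/c2ccc(C(F)(F)F)cc2)s1`, which differs from compound 2 in one place only: 4-(trifluoromethyl)phenyl in place of 2,4-dichlorophenyl on a carbonyl carbon. Nothing else in the molecule changes, and the hydrazone side with its 4-(trifluoromethyl)phenyl group is kept as in compound 2.

Among the compounds with values here, no measured pair in this set isolates this change, so there is no direct step to lean on. Given that all three measured values sit within the scatter of one another, it is expected that the step from compound 2 to compound 4 in this assay, a 1.2-fold lower number from compound 2 to compound 4 (0.09 log units; within the scatter), stays within the scatter, with no clear direction. On that basis compound 4 is estimated to give 6.5 ug/mL, with a likely range from 3 ug/mL to 14 ug/mL.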

Compound 4, half-maximal inhibitory concentration: > 100 ug/mL
Compound 4 was reported as a limit; the forecaster's own chance of this, stated with the estimate: 5%; middle value at least 15-fold (1.18 log units) away from the limit.
By their numbers in this assay, from the lowest: compounds 1, 2 and 3 (each within the scatter of the next, the first and the last beyond it). At a limit, above all of these: compound 4.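

In this assay, 4-(trifluoromethyl)phenyl in place of 2,4-dichlorophenyl on a carbonyl carbon gives an at least 12-fold higher number from compound 2 to compound 4 (1.09 log units; beyond the scatter), a large change from a single substitution on the acyl arm. Compounds 1, 2 and 3 each differ from one another in more than one place, so they could not show what this position contributes on its own; this pair shows that, with the hydrazone side held constant, the group on this carbonyl carbon can decide whether inhibition is seen at all in this read-out. For compound 4, > 100 ug/mL is a limit of the assay and not a number, so the step has no defined upper end: the limit of > 100 ug/mL in this assay, at which 1 of the 4 values shown sits.

The compounds shown leave open how much of the step goes with losing the two chlorine atoms and how much with gaining the trifluoromethyl group, as this single change does both at once. They also leave open how a methoxyphenyl or aminophenyl group on this carbonyl carbon would behave, and whether the same step appears with a different group on the hydrazone side.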